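This account rests on a few compounds, and the source may have more. Where it says the series, first, only, none or still open, it means among the compounds named here.

Compound 1 `COc1ccc(-c2cc(-c3ccc(OCc4cn(Cc5ccccc5)nn4)cc3O)nc(N)n2)cc1` gives 42700 nM 
Compound 2 `CCCCCCn1cc(COc2ccc(-c3cc(-c4ccc(OC)cc4)nc(N)n3)c(O)c2)nn1` gives "not determined" (no result reported) 
Compound 3 `O=C(/C=C/c1ccc(Br)cc1)c1ccc(OCc2cn(Cc3ccc(Br)cc3)nn2)cc1O` gives "not determined" (no result reported) 

Among the measured compounds shown here, in an ADME assay on cells (Macrophage) for cytotoxicity, read by resazurin assay, with a stated time of 48 h (a higher number here means that more compound is tolerated, a lower number that less compound is tolerated), compound 1 gives 42700 nM as the only number available, so it cannot yet be ranked against any other compound. Compound 4 `Nc1nc(-c2ccccc2)cc(-c2ccc(OCc3cn(Cc4ccccc4)nn3)cc2O)n1` keeps the rest of compound 1 but has hydrogen in place of methoxy on an aromatic carbon. In other words, 4-methoxyphenyl becomes phenyl. For the measured compounds named here, no measured pair shows what such a change does here, so no step beyond the scatter is expected in this assay, and neither direction is favoured. The expected change is small (a 1.1-fold lower number from compound 1 to compound 4 (0.03 log units; within the scatter)). For compound 4 the estimated value is 40000 nM (expected range 16000 nM to 100000 nM).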

Compound 4, half-maximal cytotoxic concentration: 76500 nM
Compound 4: the middle estimate sits 1.9-fold (0.28 log units) below what was measured; the range from low to high includes it.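

In this assay, among the compounds shown here, the swap of 4-methoxyphenyl for phenyl (a 1.8-fold higher number from compound 1 to compound 4 (0.25 log units; within the scatter)) gives the first measured pair at this position, and the two compounds stand within the usual scatter of each other. In this one pair, then, the methoxy is not required for cells to tolerate the compound at a similar concentration. Nothing measured here offers an explanation for this result. As far as these compounds go, whether an amine or a carboxylic acid in the same place would also stay within the scatter remains open. One pair also cannot show whether the same swap would read alike on a different core.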